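A piperidine for a triazole on the side chain

This account rests on a few compounds, and the source may have more. Where it says the series, first, only, none or still open, it means among the compounds named here.

Going by these compounds, measured so far in a functional assay on HCT-116 cells (Homo sapiens) for antiproliferative activity, read by sulforhodamine B assay, with a stated time of 72 h (on this read-out higher numbers stand for weaker inhibition and lower numbers for stronger inhibition), are three compounds, with a fourth still open.

Compound 1 `Cn1ncc(Cl)c1-c1cc(C(=O)N[C@@H]2CN[C@H](CC(O)CO)C[C@H]2c2ccc(Cl)c(Cl)c2)oc1Cl` gives 1110 nM
Compound 2 `Cn1ncc(Cl)c1-c1cc(C(=O)N[C@@H]2CN[C@H](CCCO)C[C@H]2c2ccc(Cl)c(Cl)c2)oc1Cl` gives 510 nM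
Compound 3 `Cn1ncc(Cl)c1-c1cc(C(=O)N[C@@H]2CN[C@H](CCn3cncn3)C[C@H]2c2ccc(Cl)c(Cl)c2)oc1Cl` gives 560 nM
Compound 4 `Cn1ncc(Cl)c1-c1cc(C(=O)N[C@@H]2CN[C@H](CCN3CCCCC3)C[C@H]2c2ccc(Cl)c(Cl)c2)oc1Cl` is not yet measured

Compound 3 cannot be told apart from the other two: a 1.1-fold higher number from compound 2 to compound 3 (0.04 log units; within the scatter) and a 2.0-fold lower number from compound 1 to compound 3 (0.30 log units; within the scatter) both lie within the scatter. Compound 4 carries piperidin-1-yl in place of 1H-1,2,4-triazol-1-yl on a saturated chain carbon, two bonds along the chain from a saturated ring carbon. Among the compounds with values here, no measured step makes this swap. Changes on the same chain stayed small: a 1.1-fold higher number from compound 2 to compound 3 (0.04 log units; within the scatter) is within the scatter and a 2.2-fold lower number from compound 1 to compound 2 (0.34 log units; beyond the scatter) is modest, so no step beyond the scatter is expected in this assay here. The estimated step is a 1.2-fold lower number from compound 3 to compound 4 (0.09 log units; within the scatter) and its direction is uncertain. Within the data shown here, no measured compound holds piperidin-1-yl, so the range stays wide. The expected value for compound 4 is 450 nM within an estimated range of 170 nM to 1200 nM.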

Compound 4, half-maximal inhibitory concentration: 1020 nM
For compound 4 the middle estimate is 2.3-fold (0.36 log units) below the measured one; measured number inside the range.
By their numbers in this assay, from the lowest: compounds 2, 3, 4 and 1 (each within the scatter of the next, the first and the last beyond it).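

In this assay this place on the chain does not separate piperidin-1-yl from 1H-1,2,4-triazol-1-yl, with a 1.8-fold higher number from compound 3 to compound 4 (0.26 log units; within the scatter). Piperidin-1-yl in place of hydroxymethyl gives a 2.0-fold higher number from compound 2 to compound 4 (0.30 log units; within the scatter) and (piperidin-1-yl)methyl in place of 1,2-dihydroxyethyl gives a 1.1-fold lower number from compound 1 to compound 4 (0.04 log units; within the scatter), so this side chain cannot be separated from any of the three earlier ones, even though compounds 1 and 2 are separated from each other. Nothing measured here explains why these groups read alike.

Going by these compounds, whether a carboxylic acid or a morpholine at this place would move the number beyond the scatter stays open. So does the effect of a longer chain carrying the piperidine.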